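Aryl variation on the sulfonyl group: compounds 1 to 4

The compounds below may be only part of what the source reports. "The series", "measured", "known", "first", "only" and "open" are said of these compounds alone.

Measured so far, in an assay on isolated protein for displacement of a labelled ligand from metabotropic glutamate receptor 5 (Homo sapiens), with a stated time of 60 min, tested at 1 uM; on this read-out lower numbers stand for less inhibition and higher numbers for more inhibition at the one concentration tested (going by the name of the read-out):
- compound 1 `COc1ccc2ncc(S(=O)(=O)c3ccc(C)cc3)c(N3CCC(C)CC3)c2c1` gives 90%
- compound 2 `COc1ccc2ncc(S(=O)(=O)c3ccc(C)c(F)c3)c(N3CCC(C)CC3)c2c1` gives 73%
- compound 3 `COc1ccc2ncc(S(=O)(=O)c3cc(C)cc(C)c3)c(N3CCC(C)CC3)c2c1` gives 79%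

Compound 3 stands second highest of the three; compound 2 is nearest, and compound 1 furthest, the gap to compound 1 being beyond the scatter while that to compound 2 is within it. The next compound, compound 4 `COc1ccc2ncc(S(=O)(=O)c3ccc(OC)c(OC)c3)c(N3CCC(C)CC3)c2c1`, differs from compound 3 by 3,4-dimethoxyphenyl in place of 3,5-dimethylphenyl on a sulfonyl sulfur.

Among the measured compounds shown here, two steps bear on this: a number 11 percentage points lower from compound 1 to compound 3 (beyond the scatter) and a number 17 percentage points lower from compound 1 to compound 2 (beyond the scatter), both modest lowerings on changing the aryl group; a number 6 percentage points higher from compound 2 to compound 3 (within the scatter) lies within the scatter. For the measured compounds named here, no compound so far carries methoxy on this aryl ring, so the direction rests on those two steps alone. A modest lowering is expected, a number 14 percentage points lower from compound 3 to compound 4 (beyond the scatter). Compound 4 is therefore estimated at 65%, with a range of 40% to 85%.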

Compound 4, a percentage reported as inhibition, at one concentration (the size of the read-out at that concentration, not a potency): -3%
Compound 4: middle estimate off by 68 percentage points, on the high side, and the stated range ends above it.
By their numbers in this assay, from the lowest: compound 4; then compounds 2 and 3 (each within the scatter of the next); then compound 1.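

Changing the aryl group on the sulfonyl sulfur can almost abolish the read-out: 3,4-dimethoxyphenyl brings large losses against 3,5-dimethylphenyl (a number 82 percentage points lower from compound 3 to compound 4 (beyond the scatter)), against 3-fluoro-4-methylphenyl (a number 76 percentage points lower from compound 2 to compound 4 (beyond the scatter)) and against 4-methylphenyl (a number 93 percentage points lower from compound 1 to compound 4 (beyond the scatter)). The methyl and fluoro aryl groups had shifted the number only modestly, so this position is far less forgiving than those compounds indicated. Nothing available accounts for the loss.

From the compounds shown here alone, whether a single methoxy group on this aryl ring gives the same loss stays open. So does the outcome with an amine or a carboxylic acid on the ring.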